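A few compounds are considered here, and "the series" means these few. Any claim that something is new, unique, unknown or untested is made for them only; others in the source may bear on it.

Compound 1 `CC1CCN(c2nc(Cl)nc3c2ncn3Cc2ccc(/C=C/C(=O)Nc3ccccc3N)cc2)CC1` stands at the low end of the three numbers shown in a functional assay on HCT-116 cells (Homo sapiens) for antiproliferative activity, read by CCK-8 assay, with a stated time of 72 h, tested at 2 uM (a higher number here means a stronger effect of the compound at the concentration tested, a lower number a weaker effect), giving 4.24%, while compound 2 `CCCCn1cnc2c(NCc3ccc(C(=O)Nc4ccccc4N)cc3)nc(Cl)nc21` gives 4.89% and compound 3 `CC(C)n1cnc2c(Nc3cccc(Cl)c3)nc(NCOCc3ccc(C(=O)Nc4ccccc4N)cc3)nc21` gives 7.12%, both within the usual scatter of compound 1, so the three cannot be ranked. Compound 4 `Nc1ccccc1NC(=O)/C=C/c1ccc(Cn2cnc3c(Nc4cccc(OC(F)(F)F)c4)nc(Cl)nc32)cc1` differs from compound 1 by (3-(trifluoromethoxy)phenyl)amino in place of 4-methylpiperidin-1-yl on an aromatic carbon. For the measured compounds named here, no pair of measured compounds differs in one place, so no measured step gives a size for this change. Since all three measured numbers sit low and close together, the step of a number 1.8 percentage points higher from compound 1 to compound 4 (within the scatter) is expected to be small, in no clear direction, and not beyond the scatter. Compound 4 is therefore estimated at 6%, with a range from 0% to 16%.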

Compound 4, a percentage reported as inhibition, at one concentration (the size of the read-out at that concentration, not a potency): 2.8%
Compound 4: middle estimate off by 3.2 percentage points, on the high side; measured number inside the range.
By their numbers in this assay, from the lowest: compounds 4, 1, 2 and 3 (each within the scatter of the next).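

For the compounds shown here, at this aromatic carbon, (3-(trifluoromethoxy)phenyl)amino in place of 4-methylpiperidin-1-yl gives the first one-place step in this assay, a number 1.4 percentage points lower from compound 1 to compound 4 (within the scatter). Replacing the non-aromatic ring with an aromatic ring and adding a hydrogen-bond donor therefore produces no difference beyond the scatter at this single concentration, and both compounds remain low. No available evidence bears on this result. From the compounds shown here alone, it remains open whether a morpholine or a primary amine at this carbon would give a number clearly beyond the scatter. A single concentration also leaves the potency of these compounds open.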